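A few compounds are considered here, and "the series" means these few. Any claim that something is new, unique, unknown or untested is made for them only; others in the source may bear on it.

Two compounds share the core of compound 1 `Cc1cc(NNC(=O)Nc2cc(Cl)nc(Cl)c2)ncc1N(C)C`. In a functional assay on CHO cells for antagonist activity at sphingosine 1-phosphate receptor 2 (Homo sapiens), read by fluorescence and calcium flux, with a stated time of 3 min (on this read-out higher numbers stand for weaker inhibition and lower numbers for stronger inhibition), compound 1 gives 3600 nM. Compound 2 `CCOC(=O)c1cc(C)cc(NNC(=O)Nc2cc(Cl)nc(Cl)c2)n1` stands at the lower of the two numbers: in this assay compound 2 gives 760 nM. Compound 3 `Cc1cc(NNC(=O)Nc2cc(Cl)nc(Cl)c2)nc(C(=O)NC2CC2)c1` has not yet been measured; it differs from compound 2 in one place: cyclopropylamino in place of ethoxy on a carbonyl carbon. Among the measured compounds shown here, no measured pair shows this change, so the size and direction of the step are open. For compound 3 the expectation in this assay is a step of about the scatter, a 1.1-fold higher number from compound 2 to compound 3 (0.02 log units; within the scatter). Compound 3 is estimated at 800 nM, with a range from 250 nM to 2500 nM.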

Compound 3, half-maximal inhibitory concentration: 4500 nM
The estimate for compound 3 lay 5.6-fold (0.75 log units) below the measured number, and the stated range ends below it.
By their numbers in this assay, from the lowest: compound 2; then compounds 1 and 3 (each within the scatter of the next).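

In this assay, among the compounds shown here, cyclopropylamino in place of ethoxy on a carbonyl carbon gives a 5.9-fold higher number from compound 2 to compound 3 (0.77 log units; beyond the scatter) as the first measured step at this place, so inhibition here depends on the group on this carbonyl carbon. The change adds a hydrogen-bond donor and a three-membered ring together, and this single step cannot separate the two. No measurement available here explains the rise in the number. Ethylamino on the same carbonyl carbon would test the amine without the ring, and a carboxylic acid or a longer alkoxy chain remains open as well.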